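An ethoxycarbonyl group added to compound 1

A few compounds are considered here, and "the series" means these few. Any claim that something is new, unique, unknown or untested is made for them only; others in the source may bear on it.

Three compounds share one core and differ only in the fluorophenyl group on an amide-type nitrogen. Compound 1 `O=C(Nc1ccccc1F)N1c2ccnn2CC1c1ccccc1` carries 2-fluorophenyl, compound 2 `O=C(Nc1cccc(F)c1)N1c2ccnn2CC1c1ccccc1` carries 3-fluorophenyl, and compound 3 `O=C(Nc1ccc(F)cc1)N1c2ccnn2CC1c1ccccc1` carries 4-fluorophenyl. In a functional assay on cells (Neutrophil, Homo sapiens) for inhibition, with a stated time of 10 min (a higher number here means a weaker inhibitor, a lower number a stronger inhibitor), compound 1 gives > 1000 nM, which is a limit and not a number. Compound 2 gives > 1000 nM, also a limit. Compound 3 gives > 1000 nM, again a limit. The whole record so far is thus (the limit of > 1000 nM in this assay, at which 3 of the 3 values shown sit).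

Compound 4 `CCOC(=O)c1cnn2c1N(C(=O)Nc1ccccc1F)C(c1ccccc1)C2` keeps the 2-fluorophenyl of compound 1 and differs in one place: ethoxycarbonyl in place of hydrogen on an aromatic carbon. The measured steps are a step that the two limits leave unreadable from compound 1 to compound 2, a step that the two limits leave unreadable from compound 1 to compound 3 and a step that the two limits leave unreadable from compound 2 to compound 3. None has a readable size, and all three concern the fluorophenyl group, so none tests the place where compound 4 changes.

The expectation therefore starts from compound 1, whose > 1000 nM is a limit. No direction follows from these data, so only a modest shift in this assay is expected, and another limit is quite possible. The expected change is a step that the limit leaves unreadable from compound 1 to compound 4. For compound 4 the estimated value is 1500 nM, with an expected range from 100 nM to 10000 nM.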

Compound 4, half-maximal inhibitory concentration: 7.5 nM
Compound 4: middle estimate off by 200-fold (2.30 log units), on the high side; the measured number lies below the stated range.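

The fluorophenyl changes among compound 1, compound 2 and compound 3 gave steps that cannot be read, and the record stayed at a single ceiling: the limit of > 1000 nM in this assay, at which 3 of the 4 values shown sit. The aromatic carbon of the five-membered aromatic ring with 2 nitrogen is the first place shown where one change has a readable effect, with ethoxycarbonyl in place of hydrogen giving an at least 130-fold lower number from compound 1 to compound 4 (2.12 log units; beyond the scatter) in this assay. For the compounds shown here, compound 4, at 7.5 nM, is the only one of the four compounds with an actual number. The size of its step is a minimum, set by the limit on compound 1.

On these data alone, it remains open which part of the ethoxycarbonyl group goes with this gain: a carboxylic acid, a primary amide or a methyl ester on the same carbon would separate the carbonyl from the ethyl chain. It is also open whether the fluorine position matters once ethoxycarbonyl is in place, as among the compounds shown 3-fluorophenyl and 4-fluorophenyl appear only without it.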